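Cyanophenyl for methylphenyl on a shared acid core

This account rests on a few compounds, and the source may have more. Where it says the series, first, only, none or still open, it means among the compounds named here.

The measured compounds, in an in vitro functional assay on cells for agonist activity at Bombesin receptor subtype-3 (Homo sapiens), read by luminescence and calcium flux; a lower number here means that less compound is needed, a higher number that more compound is needed for the effect:
- compound 1, `CCCCc1cnc(Cc2ccc(-c3ccccc3C(=O)O)cc2)[nH]1`: compound 1 gives > 10000 nM, which is a limit of the assay and not a number.
- compound 2, `CCCCc1cnc(C(C)Cc2ccc(-c3ccccc3C(=O)O)cc2)[nH]1`: compound 2 gives 2760 nM.
- compound 3, `Cc1ccccc1Cc1cnc(CCc2ccc(-c3ccccc3C(=O)O)cc2)[nH]1`: compound 3 gives 127 nM.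

Compound 3 stands lowest of the two numbers in this assay; the nearest is compound 2, and the gap between them lies beyond the usual scatter. Compound 1 sits at the limit, as noted in the limit of > 10000 nM in this assay, at which 1 of the 3 values shown sits.

Compound 4, `N#Cc1ccc(Cc2cnc(CCc3ccc(-c4ccccc4C(=O)O)cc3)[nH]2)cc1`, has not yet been measured. It differs from compound 3 in one place: 4-cyanophenyl in place of 2-methylphenyl on a saturated chain carbon bound to an aromatic carbon. Going by the values given here, no pair of measured compounds shows this kind of change, so there is no measured step to lean on. The expectation is a modest step in this assay, in either direction, of a size that could still lie within the scatter. Compound 4 is therefore estimated at 250 nM, between 40 nM and 1500 nM, which would be a step from compound 3 to compound 4 of a 2.0-fold higher number from compound 3 to compound 4 (0.29 log units; within the scatter).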

Compound 4, half-maximal effective concentration: 5890 nM
Estimate against measurement, compound 4: 24-fold (1.37 log units) below; measured number outside the range, above it.
By their numbers in this assay, from the lowest: compound 3; then compound 2; then compound 4. At a limit, above all of these: compound 1.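

Going by these compounds alone, this is the first measured step at this place, on a saturated chain carbon bound to an aromatic carbon, and it shows that the number in this assay depends strongly on the group carried there: 4-cyanophenyl in place of 2-methylphenyl gives a 46-fold higher number from compound 3 to compound 4 (1.67 log units; beyond the scatter). The change replaces the methyl with a nitrile and also moves the substituent to a different ring position, so this single step cannot assign the rise to either alteration. Nothing measured here gives a reason for the step.

The compounds shown leave open whether the nitrile or the new ring position accounts for the rise. A 2-cyanophenyl or a 4-methylphenyl group at this place would separate the two, and an unsubstituted phenyl group would show what the methyl and the nitrile each contribute.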